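Swapping Isobutyl for 2-Methylbenzyl at the Sulfur-Bound Carbon

The source may hold more compounds than are shown below. What is called first, only, known or untested is meant among the compounds shown, and "the series" means these compounds.

Going by the values given here, compound 2 `CC(C)CSc1n[nH]c(-n2[se]c3ccccc3c2=O)n1` is the only compound with a number in a functional assay on HeLa cells (Homo sapiens) for antiproliferative activity, read by CCK-8 assay, with a stated time of 48 h; on this read-out lower numbers stand for stronger inhibition and higher numbers for weaker inhibition: compound 2 gives 34900 nM. Compound 1 `O=c1c2ccccc2[se]n1-c1nc(SCc2ccccc2)n[nH]1` reaches only a limit in this assay, > 50000 nM. Among the compounds with values here, the step of an at least 1.4-fold lower number from compound 1 to compound 2 (0.15 log units; that floor lies within the scatter) is the single measured comparison, and it is bounded by the limit of > 50000 nM in this assay, at which 1 of the 2 values shown sits. Compound 3 `Cc1ccccc1CSc1n[nH]c(-n2[se]c3ccccc3c2=O)n1` differs from compound 2 by 2-methylphenyl in place of isopropyl on a saturated chain carbon bound to a sulfur. This roughly reverses the measured step, returning a ring to that carbon, so compound 3 is expected to move back toward the limit, an expected step of a 1.3-fold higher number from compound 2 to compound 3 (0.11 log units; within the scatter). Compound 3 is estimated at 45000 nM, between 22000 nM and 100000 nM.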

Compound 3, half-maximal inhibitory concentration: 6130 nM
For compound 3 the middle estimate is 7.3-fold (0.87 log units) above the measured one, and the stated range ends above it.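

In this assay, a ring at this sulfur-bound carbon can outperform the open chain: 2-methylphenyl in place of isopropyl gives a 5.7-fold lower number from compound 2 to compound 3 (0.76 log units; beyond the scatter). The ring alone does not account for this, as a single methyl in place of hydrogen on an aromatic carbon gives an at least 8.1-fold lower number from compound 1 to compound 3 (0.91 log units; beyond the scatter). That second step is only a floor, since compound 1 stands at a limit of the assay: the limit of > 50000 nM in this assay, at which 1 of the 3 values shown sits.

The compounds shown leave open whether a chlorine or methoxy group on the ring could stand in for the methyl. They also leave open how an amine on the sulfur-bound chain would fare.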